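Dimethoxyphenyl replaces chlorophenyl on an indole acrylic acid core

The source may report more compounds than this note shows. Statements on the series, on what has been measured and on what is new or still open speak of the compounds shown alone.

Three compounds share a common core and differ only in the aryl group that sits on the double-bonded chain carbon next to the acid. Compound 1 `CC(=O)n1cc(/C=C(/C(=O)O)c2ccccc2)c2cc(OCc3ccccc3)ccc21` carries a plain phenyl there and in a functional assay on DU-145 cells (Homo sapiens) for cytotoxicity, read by MTT assay, with a stated time of 72 h (on this read-out lower numbers stand for stronger inhibition and higher numbers for weaker inhibition), compound 1 gives 26700 nM. Compound 2 `COc1cc(/C(=C\c2cn(C(C)=O)c3ccc(OCc4ccccc4)cc23)C(=O)O)cc(OC)c1OC` carries a 3,4,5-trimethoxyphenyl and in this assay compound 2 gives 950 nM. Compound 3 `CC(=O)n1cc(/C=C(/C(=O)O)c2ccc(Cl)cc2)c2cc(OCc3ccccc3)ccc21` carries a 4-chlorophenyl and in this assay compound 3 gives 1130 nM, the second highest of the three numbers; its neighbour is compound 2, as the step of a 1.2-fold higher number from compound 2 to compound 3 (0.08 log units; within the scatter) shows, while compound 1 lies far off, as the step of a 24-fold lower number from compound 1 to compound 3 (1.37 log units; beyond the scatter) shows.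

Compound 4 `COc1ccc(/C(=C\c2cn(C(C)=O)c3ccc(OCc4ccccc4)cc23)C(=O)O)cc1OC` is not yet measured. The change from compound 3 is 3,4-dimethoxyphenyl in place of 4-chlorophenyl on a double-bonded chain carbon bound to a carbonyl carbon and a double-bonded chain carbon. Going by the values given here, two measured steps bear on it: adding a chloro to the phenyl, a 24-fold lower number from compound 1 to compound 3 (1.37 log units; beyond the scatter), and adding three methoxy groups to the phenyl, a 28-fold lower number from compound 1 to compound 2 (1.45 log units; beyond the scatter), both large and both toward lower numbers, and the swap between those two substituted phenyls, a 1.2-fold higher number from compound 2 to compound 3 (0.08 log units; within the scatter), changed little. A dimethoxyphenyl is therefore expected to land near both substituted analogues, so for compound 4 the expected step is a 1.3-fold higher number from compound 3 to compound 4 (0.12 log units; within the scatter), within the scatter. Compound 4 is estimated at 1500 nM, in the range 500 nM to 5000 nM.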

Compound 4, half-maximal inhibitory concentration: 1050 nM
The estimate for compound 4 lay 1.4-fold (0.15 log units) above the measured number, within the range that was stated.
By their numbers in this assay, from the lowest: compounds 2, 4 and 3 (each within the scatter of the next); then compound 1.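

In this assay, the 3,4-dimethoxyphenyl on this double-bonded chain carbon can stand in for the 4-chlorophenyl, with a 1.1-fold lower number from compound 3 to compound 4 (0.03 log units; within the scatter), and one methoxy of the 3,4,5-trimethoxyphenyl can give way to hydrogen, with a 1.1-fold higher number from compound 2 to compound 4 (0.04 log units; within the scatter). A third substituted phenyl now stands apart from the plain phenyl, with a 25-fold lower number from compound 1 to compound 4 (1.41 log units; beyond the scatter), so among these four compounds the large drop appears with a chloro, with two methoxy groups and with three, and only compound 1, with no substituent on its phenyl, stays far off. No measurement here explains why such different substituents give numbers within the scatter of one another.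

The compounds shown leave open whether a single methoxy on the phenyl would be enough, and whether a phenyl carrying an amine, a hydroxyl or a fluoro would join this group of numbers or fall back toward compound 1. As far as these compounds go, all four also keep the carboxylic acid, so the effect of a methyl ester in its place remains unknown.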